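The compounds below may be only part of what the source reports. "The series", "measured", "known", "first", "only" and "open" are said of these compounds alone.

In a functional assay on K562 cells (Homo sapiens) for antiproliferative activity, read by MTT assay, with a stated time of 72 h (a lower number here means a stronger inhibitor, a higher number a weaker inhibitor), compound 3 `COc1ccc(OC)c(-c2c(C(=O)c3cc(OC)c(OC)c(OC)c3)sc3ccccc23)c1` gives > 10000 nM, which is a limit and not a number. Compound 1 `COc1ccccc1-c1c(C(=O)c2cc(OC)c(OC)c(OC)c2)sc2ccccc12` gives 3400 nM and compound 2 `COc1ccc(-c2c(C(=O)c3cc(OC)c(OC)c(OC)c3)sc3ccccc23)c(OC)c1` gives 4100 nM, with a 1.2-fold higher number from compound 1 to compound 2 (0.08 log units; within the scatter). Compound 4 `COc1cc(C(=O)c2sc3ccccc3c2Nc2ccc(C)cc2)cc(OC)c1OC` differs from compound 3 by (4-methylphenyl)amino in place of 2,5-dimethoxyphenyl on an aromatic carbon. Among the compounds with values here, no measured step covers this replacement. The nearest guides are an at least 2.9-fold higher number from compound 1 to compound 3 (0.46 log units; beyond the scatter) and an at least 2.4-fold higher number from compound 2 to compound 3 (0.38 log units; beyond the scatter), both at least modest. Removing the 2,5-dimethoxyphenyl of compound 3 is therefore expected to give a modest move to a lower number in this assay, near the level of compound 1 at 3400 nM. The expected result is an at least 5.0-fold lower number from compound 3 to compound 4 (0.69 log units; beyond the scatter). For compound 4 the estimate is 2000 nM, with an expected range of 200 nM to 9000 nM.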

Compound 4, half-maximal inhibitory concentration: 1600 nM
Compound 4: the middle estimate sits 1.3-fold (0.10 log units) above what was measured, and the stated range covers the measured number.
By their numbers in this assay, from the lowest: compound 4; then compounds 1 and 2 (each within the scatter of the next). At a limit, above all of these: compound 3.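

In this assay, within the data shown here, this position on the five-membered ring accepts a ring joined through nitrogen: (4-methylphenyl)amino gives a 2.1-fold lower number from compound 1 to compound 4 (0.33 log units; beyond the scatter) and a 2.6-fold lower number from compound 2 to compound 4 (0.41 log units; beyond the scatter), the first change here to fall below both methoxyphenyl compounds with numbers. The third step, an at least 6.2-fold lower number from compound 3 to compound 4 (0.79 log units; beyond the scatter), is open-ended. Compound 3 stands at a limit and not a number: the limit of > 10000 nM in this assay, at which 1 of the 4 values shown sits.

Whether the amino hydrogen or the methyl of the (4-methylphenyl)amino group accounts for the gain stays open. A methylated amino link and a plain phenylamino group would separate the two.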